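This account rests on a few compounds, and the source may have more. Where it says the series, first, only, none or still open, it means among the compounds named here.

Measured compounds:
compound 1, `COc1cc(-c2nnc3n2NC(c2ccco2)C(C(=O)c2ccccc2C)S3)cc(OC)c1OC`, which in a functional assay on MCF7 cells (Homo sapiens) for cytotoxicity, read by MTT assay, with a stated time of 48 h (on this read-out higher numbers stand for weaker inhibition and lower numbers for stronger inhibition), gives 69900 nM;
compound 2, `COc1cc(-c2nnc3n2NC(c2ccco2)C(C(=O)C2CC2)S3)cc(OC)c1OC`, whose read-out in this assay is a limit of the assay, > 100000 nM.

Compound 2 thus stands at the limit of this assay, the limit at which one of the two values sits, as noted in the limit of > 100000 nM in this assay, at which 1 of the 2 values shown sits. The step from compound 1 to compound 2 reads an at least 1.4-fold higher number from compound 1 to compound 2 (0.15 log units; that floor lies within the scatter); its floor lies within the scatter, so the two compounds cannot be ordered with confidence.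

Compound 3, `COc1cc(-c2nnc3n2NC(c2ccco2)C(C(=O)c2ccc(F)c(F)c2)S3)cc(OC)c1OC`, has not yet been measured in this assay. It differs from compound 2 by 3,4-difluorophenyl in place of cyclopropyl on a carbonyl carbon. Within the data shown here, only one measured step bears on this change: an at least 1.4-fold higher number from compound 1 to compound 2 (0.15 log units; that floor lies within the scatter), which replaced the 2-methylphenyl group on the same carbonyl carbon by cyclopropyl and ran toward the limit. Restoring a phenyl-type group, now 3,4-difluorophenyl, is therefore expected to move the number back toward that of compound 1, by a step of an at least 1.2-fold lower number from compound 2 to compound 3 (0.09 log units; that floor lies within the scatter), though a second limit value remains quite possible. Compound 3 is estimated at 80000 nM, within a range from 35000 nM to 200000 nM.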

Compound 3, half-maximal inhibitory concentration: 73200 nM
Compound 3: middle estimate off by 1.1-fold (0.04 log units), on the high side; measured number inside the range.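

On this carbonyl carbon, putting 3,4-difluorophenyl in place of cyclopropyl gives in this assay an at least 1.3-fold lower number from compound 2 to compound 3 (0.13 log units; that floor lies within the scatter), so a measured number now stands on this position with a second phenyl-type group, although the floor of this step does not order the two compounds. Replacing 2-methylphenyl by 3,4-difluorophenyl on the same carbon gives a 1.0-fold higher number from compound 1 to compound 3 (0.02 log units; within the scatter), so these two substituted phenyl groups cannot be told apart in this read-out, and neither the methyl group nor the two fluorine atoms separate the compounds. Among these three compounds, only the cyclopropyl compound lacks a measured number, and compound 2 is held at a limit rather than a number: the limit of > 100000 nM in this assay, at which 1 of the 3 values shown sits.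

As far as these compounds go, how far the number of compound 2 lies from those of the two phenyl-type compounds remains open, and with it whether the cyclopropyl change has any real size. From the compounds shown here alone, it is also open whether an unsubstituted phenyl, a pyridine ring, a longer alkyl chain or an amine on this carbonyl carbon would move the number beyond the scatter.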